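This account rests on a few compounds, and the source may have more. Where it says the series, first, only, none or still open, it means among the compounds named here.

Measured so far:
compound 1 `CC(C)=C1C(=O)N(c2ccc(Cl)cc2)N(c2ccc(Cl)cc2)C1=O` — 42100 nM
compound 2 `CCC(C)=C1C(=O)N(c2ccc(Cl)cc2)N(c2ccc(Cl)cc2)C1=O` — 41100 nM
compound 3 `O=C1C(=Cc2ccc(O)cc2)C(=O)N(c2ccc(Cl)cc2)N1c1ccc(Cl)cc1` — 34200 nM

In a functional assay on ECa-109 cells (Homo sapiens) for cytotoxicity, read by MTT assay, with a stated time of 72 h (a lower number here means a stronger inhibitor, a higher number a weaker inhibitor), compound 3 gives the lowest of the three numbers, but its gaps to compound 2 and to compound 1 both lie within the scatter, so the three are not separated. Compound 4 `CC(=C1C(=O)N(c2ccc(Cl)cc2)N(c2ccc(Cl)cc2)C1=O)c1ccc(O)cc1` differs from compound 3 by methyl in place of hydrogen on a double-bonded chain carbon bound to an aromatic carbon and a double-bonded ring carbon. Going by the values given here, the only measured step of a related kind is a 1.0-fold lower number from compound 1 to compound 2 (0.01 log units; within the scatter), a methyl entering on a saturated chain carbon bound to a double-bonded chain carbon, a different place from the present change. Among the compounds with values here, that step stayed within the scatter, and nothing among the measured compounds points to a larger effect here. Compound 4 is therefore expected to give 34000 nM, between 17000 nM and 68000 nM. The expected step is a 1.0-fold lower number from compound 3 to compound 4 (0.00 log units; within the scatter), no change beyond the scatter.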

Compound 4, half-maximal inhibitory concentration: 55600 nM
Compound 4: the middle estimate sits 1.6-fold (0.21 log units) below what was measured, and the stated range covers the measured number.
By their numbers in this assay, from the lowest: compounds 3, 2, 1 and 4 (each within the scatter of the next).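

In this assay the double-bonded chain carbon bound to an aromatic carbon and a double-bonded ring carbon accepts methyl in place of hydrogen, with a 1.6-fold higher number from compound 3 to compound 4 (0.21 log units; within the scatter) as the step. The same carbon also accepts 4-hydroxyphenyl, with a 1.4-fold higher number from compound 2 to compound 4 (0.13 log units; within the scatter) for the group in place of ethyl and a 1.3-fold higher number from compound 1 to compound 4 (0.12 log units; within the scatter) for the group in place of methyl. None of these changes separates the compounds, so this carbon has so far tolerated both alkyl and aryl groups. Still open, going by these compounds, is whether an amine or a carboxylic acid at this carbon would give a step beyond the scatter. No measured evidence bears on these steps.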